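The source may report more compounds than this note shows. Statements on the series, on what has been measured and on what is new or still open speak of the compounds shown alone.

In a functional assay on L1210 cells (Mus musculus) for inhibition, read by MTT assay, with a stated time of 72 h (a higher number here means a weaker inhibitor, a lower number a stronger inhibitor), compound 1 (`COc1cc(NC(C)CCCNC(=O)NNC(=O)Nc2ccc(Br)cc2)c2ncccc2c1`) gives 51000 nM, while compound 2 (`COc1cc(NC(C)CCCNC(=O)Nc2ccc(C(F)(F)F)cc2)c2ncccc2c1`) gives 7400 nM. Compound 2 therefore holds the lower of the two numbers and is the stronger inhibitor so far. The next compound to be tested, compound 3 (`COc1cc(NC(C)CCCNC(=O)Nc2ccc(O)cc2)c2ncccc2c1`), keeps everything in compound 2 except one group on the aromatic ring: hydroxy in place of trifluoromethyl on an aromatic carbon. In words, hydroxy takes the place of trifluoromethyl on an aromatic carbon.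

Among the measured compounds shown here, only one measured step offers any guidance, and that guidance is limited. a 6.9-fold lower number from compound 1 to compound 2 (0.84 log units; beyond the scatter) is a modest change, and it shows how far a change at this end of the molecule can move the number in this assay. However, that step does not exchange these two groups, so no measurement yet compares hydroxy with trifluoromethyl directly. A step of similar modest size is a reasonable expectation. For the measured compounds named here, the direction is uncertain, but with compound 2 at 7400 nM, the lowest number so far, a move toward weaker inhibition seems more likely. The expected change is a 2.4-fold higher number from compound 2 to compound 3 (0.39 log units; beyond the scatter). For compound 3, the estimated value is 18000 nM, with an expected range from 5000 nM to 60000 nM.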

Compound 3, half-maximal inhibitory concentration: 21000 nM
For compound 3 the middle estimate is 1.2-fold (0.07 log units) below the measured one; low and high end bracket the measured number.
By their numbers in this assay, from the lowest: compound 2; then compound 3; then compound 1.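

Among the compounds shown here, this is the first direct exchange at this spot, on an aromatic carbon para to a large group. In this assay, hydroxy in place of trifluoromethyl gives a 2.8-fold higher number from compound 2 to compound 3 (0.45 log units; beyond the scatter) and shows that the group held here matters, with trifluoromethyl the stronger of the two. Compound 3 still improves on compound 1, as a 2.4-fold lower number from compound 1 to compound 3 (0.39 log units; beyond the scatter) shows, so 4-hydroxyphenyl in place of the longer end group of compound 1 gains ground, but less than 4-(trifluoromethyl)phenyl does, and no measurement at hand says why the number moves with these groups.

The compounds shown leave open how other groups on this same aromatic carbon would read, such as an amine, a carboxylic acid or a single chlorine atom, and whether any of them would fall outside the span set by trifluoromethyl and hydroxy. They also leave open whether a longer chain in place of the present one would shift the numbers, and whether the order of trifluoromethyl and hydroxy would then stay the same.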